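This account rests on a few compounds, and the source may have more. Where it says the series, first, only, none or still open, it means among the compounds named here.

Compound 1 `C(=N/c1nnc(SCc2c[se]c(-c3ccccc3)n2)s1)\c1ccccc1`: 46500 nM
Compound 2 `Oc1ccc(/C=N/c2nnc(SCc3c[se]c(-c4ccccc4)n3)s2)cc1`: > 100000 nM

In a functional assay on L1210 cells (Mus musculus) for antiproliferative activity, read by CCK-8 assay (a lower number here means a stronger inhibitor, a higher number a weaker inhibitor), compound 1 gives 46500 nM. For compound 2 the reading is only a limit of the assay, > 100000 nM, so compound 2 stands at the weak end of the numbers shown, at the limit of > 100000 nM in this assay, at which 1 of the 2 values shown sits. Going by the values given here, the single measured step, an at least 2.1-fold higher number from compound 1 to compound 2 (0.33 log units; beyond the scatter), therefore weakened inhibition. Compound 3 `Cc1ccc(/C=N/c2nnc(SCc3c[se]c(-c4ccccc4)n3)s2)cc1` differs from compound 2 by methyl in place of hydroxy on an aromatic carbon. Compound 3 is expected to recover much of that loss, an at least 1.6-fold lower number from compound 2 to compound 3 (0.22 log units; that floor lies within the scatter), since compound 1 gave 46500 nM without the hydroxy. Compound 3 is thus estimated at 60000 nM, with a range from 20000 nM to 150000 nM.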

Compound 3, half-maximal inhibitory concentration: 58600 nM
For compound 3 the middle estimate is 1.0-fold (0.01 log units) above the measured one; the range from low to high includes it.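

Methyl in place of hydroxy at this position, para to a large group, gives an at least 1.7-fold lower number from compound 2 to compound 3 (0.23 log units; that floor lies within the scatter). From the compounds shown here alone, compound 2 reads only as a limit of the assay, so the full size of that step stays unknown. Methyl in place of hydrogen gives a 1.3-fold higher number from compound 1 to compound 3 (0.10 log units; within the scatter), so this position accepts a methyl without a clear change, and among these compounds only hydroxy weakens the number. Going by these compounds, whether an amine or a carboxylic acid here would follow hydroxy or methyl remains open, as does the effect of a longer chain such as propyl.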